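The source may hold more compounds than are shown below. What is called first, only, known or untested is meant among the compounds shown, and "the series" means these compounds.

In an ADME assay on cells (Homo sapiens) for cytotoxicity, read by polymerase chain reaction, with a stated time of 3 days (on this read-out lower numbers stand for higher toxicity in this test and higher numbers for lower toxicity in this test), compound 1 `COc1ccc2nc(-c3c(Cl)nc(N)nc3N[C@@H]3C[C@H](CO)[C@@H](O)[C@H]3O)sc2c1` reaches only the assay limit, reported as > 25000 nM. Compound 2 `CCOc1ccc2nc(-c3c(Cl)nc(N)nc3N[C@@H]3C[C@H](CO)[C@@H](O)[C@H]3O)sc2c1`, which carries methyl in place of hydrogen on a saturated chain carbon bound to an oxygen on an aromatic ring, also stops at the limit, > 25000 nM. The step that the two limits leave unreadable from compound 1 to compound 2 therefore cannot be sized, and the limit of > 25000 nM in this assay, at which 2 of the 3 values shown sit, is all that these two values show. Compound 3 `Cc1nc(NC(C)C)nc(N[C@@H]2C[C@H](CO)[C@@H](O)[C@H]2O)c1-c1nc2ccccc2s1` has a different core; the difference between the two cores is not broken down here. In this assay, for the measured compounds named here, compound 3 gives 13000 nM, the only number among the three. Compound 4 `Cc1nc(NC(C)(C)C)nc(N[C@@H]2C[C@H](CO)[C@@H](O)[C@H]2O)c1-c1nc2ccccc2s1`, still unmeasured, differs from compound 3 by methyl in place of hydrogen on a saturated chain carbon bound to a nitrogen on an aromatic ring and two saturated chain carbons; this is the same kind of change as from compound 1 to compound 2, though there the carbon is bound to an oxygen on an aromatic ring and here to a nitrogen on an aromatic ring and two saturated chain carbons. With no readable step to lean on, the step from compound 3 to compound 4 is expected to be small, a 1.1-fold lower number from compound 3 to compound 4 (0.03 log units; within the scatter), and compound 4 is estimated at 12000 nM, within 4000 nM to 30000 nM.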

Compound 4, half-maximal cytotoxic concentration: 12000 nM
Compound 4: middle estimate and measured number agree at the digits printed; the range from low to high includes it.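

In this assay replacing isopropyl with tert-butyl gives a 1.1-fold lower number from compound 3 to compound 4 (0.03 log units; within the scatter) and so, on this core, the added methyl leaves the read-out within the usual scatter. The same kind of change on the core of compound 1, there on a carbon bound to an oxygen on an aromatic ring, cannot be read, because compound 1 and compound 2 both give limits of the assay and not numbers: the limit of > 25000 nM in this assay, at which 2 of the 4 values shown sit. One readable step on one core therefore shows neither that the change carries across cores nor that it does not.

On these data alone, what a longer chain, an amine or a carboxylic acid at this place would do remains open. Also open, as far as these compounds go, is how any such group would behave on the core of compound 1.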